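This account rests on a few compounds, and the source may have more. Where it says the series, first, only, none or still open, it means among the compounds named here.

The measured compounds:
compound 1, `COc1ccc(-c2ccc(-c3ccc(C(=N)N)cc3)s2)cc1`, giving 665 nM
compound 2, `COc1ccc(-c2ccc(-c3ccc(C(=N)N)c(F)c3)s2)cc1`, giving 11000 nM
compound 3, `COc1cc(OC)cc(-c2ccc(-c3ccc(C(=N)N)cc3)s2)c1`, giving 1920 nM

All three were tested in a functional assay on NCI-H23 cells (Homo sapiens) for inhibition, read by sulforhodamine B assay, with a stated time of 48 h; a higher number here means a weaker inhibitor of growth, a lower number a stronger inhibitor of growth. Compound 1 has the lowest number of the three. Compound 3, which carries a second methoxy on the same ring as the first, gives 1920 nM, a number beyond the scatter above compound 1. Compound 2 gives 11000 nM, far higher still.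

Compound 4, `N=C(N)c1ccc(-c2ccc(-c3ccc(Cl)cc3)s2)cc1`, differs from compound 1 in one place: chloro in place of methoxy on an aromatic carbon. Within the data shown here, the only measured single step is a 17-fold higher number from compound 1 to compound 2 (1.22 log units; beyond the scatter), and that change sits on the ring that carries the amidine, not on the ring changed here, so it bears only loosely on the present step. The pair of compound 1 and compound 3 shows that altering the substitution on the ring in question moved the number moderately, but in that case a group was added rather than swapped. For compound 4 a modest step, likely toward a higher number, is expected: a 1.5-fold higher number from compound 1 to compound 4 (0.18 log units; within the scatter). The estimate for compound 4 is 1000 nM, within the range 300 nM to 3500 nM.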

Compound 4, concentration for 50% growth inhibition: 190 nM
The estimate for compound 4 lay 5.3-fold (0.72 log units) above the measured number; the measured number lies below the stated range.
By their numbers in this assay, from the lowest: compound 4; then compound 1; then compound 3; then compound 2.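

In this assay, chloro in place of methoxy gives a 3.5-fold lower number from compound 1 to compound 4 (0.54 log units; beyond the scatter), a modest step beyond the scatter, whereas the only other single step shown, fluoro in place of hydrogen, gives a 17-fold higher number from compound 1 to compound 2 (1.22 log units; beyond the scatter). The methoxy, with its hydrogen-bond acceptor, is therefore not required at this place for growth inhibition, since chloro, which has no such acceptor, gives the lower number. Nothing available explains why the number fell.

From the compounds shown here alone, it remains open whether this lower number is particular to chloro or would also come with bromo, a plain hydrogen, an amine or a carboxylic acid at this place. Going by these compounds, it is also open whether the same swap would lower the number in compound 2, which carries the fluoro.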